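A few compounds are considered here, and "the series" means these few. Any claim that something is new, unique, unknown or untested is made for them only; others in the source may bear on it.

Compound 1 (`C[C@H](Oc1ccc2ncc(/C=C/S(=O)(=O)O)c(C3CC3)c2c1)c1c(Cl)ccc(F)c1Cl`) gives 2.5 in a physicochemical assay for lipophilicity, using the shake flask method (on this read-out higher numbers stand for higher lipophilicity and lower numbers for lower lipophilicity), and stands second highest of the three measured compounds. Compound 2 (`C[C@H](Oc1ccc2c(c1)c(C1CC1)c(/C=C/C(=O)O)c[n+]2[O-])c1c(Cl)ccc(F)c1Cl`) lies lower at 1.7 and compound 3 (`C[C@H](Oc1ccc2ncc(/C=C/c3nn[nH]n3)c(C3CC3)c2c1)c1c(Cl)cccc1Cl`) lies higher at 4.3 with both gaps to compound 1 beyond the scatter. Compound 4 (`C[C@H](Oc1ccc2ncc(/C=C/C(=O)O)c(C3CC3)c2c1)c1c(Cl)ccc(F)c1Cl`) carries carboxy in place of sulfo on a double-bonded chain carbon bound to a double-bonded chain carbon. Within the data shown here, no two measured compounds differ in one place, so this step has no direct precedent and the expectation remains tentative. An upward move is expected, an estimated a number 0.70 log units higher from compound 1 to compound 4 (beyond the scatter) that would lie beyond the scatter. For compound 4 the expected value in this assay is 3.2 with an estimated range from 2.6 to 3.8 as its span.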

Compound 4, distribution coefficient: 4.1
The estimate for compound 4 lay 0.90 log units below the measured number; the whole stated range lies below it.
By their numbers in this assay, from the lowest: compound 2; then compound 1; then compounds 4 and 3 (each within the scatter of the next).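

Among these compounds, this is the first single-place step: in this assay, carboxy in place of sulfo on a double-bonded chain carbon bound to a double-bonded chain carbon gives a number 1.60 log units higher from compound 1 to compound 4 (beyond the scatter), a large step. The read-out at this place therefore depends strongly on which of these two groups is present. Among the compounds shown here, nothing measured so far accounts for the size of this step. Going by these compounds, how a primary amide or a phosphono group would read at this place remains open. On these data alone, whether the same exchange gives a step of similar size on a different core also remains open.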